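From 4-methylphenyl to 4-ethylphenyl in compound 3

The compounds below may be only part of what the source reports. "The series", "measured", "known", "first", "only" and "open" are said of these compounds alone.

- Compound 1 `COC1=C(C)C(=O)/C(=C(O)/C=C/c2ccc(O)cc2)C(=O)C1(C)C`: 14.9 ug/mL
- Compound 2 `COC1=C(C)C(=O)/C(=C(O)/C=C/c2ccc(C)cc2)C(=O)C1(C)C`: 5.1 ug/mL

In a functional assay on A-431 cells (Homo sapiens) for cytotoxicity (on this read-out higher numbers stand for an effect only at larger amounts of compound and lower numbers for an effect already at smaller amounts), compound 2 has the lower of the two numbers, at 5.1 ug/mL. Compound 3 `CCc1ccc(/C=C/C(O)=C2/C(=O)C(C)=C(OC)C(C)(C)C2=O)cc1` carries one change from compound 2: methyl in place of hydrogen on a saturated chain carbon bound to an aromatic carbon. In words, methyl takes the place of hydrogen on a saturated chain carbon bound to an aromatic carbon, turning methyl into ethyl. Going by the values given here, the only measured step, a 2.9-fold lower number from compound 1 to compound 2 (0.47 log units; beyond the scatter), is modest and swaps hydroxy for methyl on an aromatic carbon, which is a different kind of change. It offers only weak guidance, so no step beyond the scatter is expected here. The expected step is a 1.1-fold lower number from compound 2 to compound 3 (0.05 log units; within the scatter). For compound 3 the estimated value is 4.5 ug/mL, with an expected range of 2.2 ug/mL to 9.5 ug/mL.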

Compound 3, concentration for half-maximal effect: 12 ug/mL
Compound 3: the middle estimate sits 2.7-fold (0.43 log units) below what was measured, outside the stated range (above it).
By their numbers in this assay, from the lowest: compound 2; then compounds 3 and 1 (each within the scatter of the next).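

Adding a single methyl at this place is not a neutral change: going from methyl to ethyl gives a 2.4-fold higher number from compound 2 to compound 3 (0.37 log units; beyond the scatter) in this assay and gives up the gain seen with methyl. Ethyl and hydroxy are not separated here, with a 1.2-fold lower number from compound 1 to compound 3 (0.09 log units; within the scatter), which leaves compound 2 with the lowest number of the three. No measured evidence explains this sensitivity to one added carbon. As far as these compounds go, whether a longer chain such as propyl, or an amine or methoxy group in this place, would fall nearer compound 2 or compound 3 remains open.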